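Swapping Chloro for Methyl on an Aromatic Carbon

The source may report more compounds than this note shows. Statements on the series, on what has been measured and on what is new or still open speak of the compounds shown alone.

For the measured compounds named here, in a functional assay on NFS-60 cells (Mus musculus) for inhibition, with a stated time of 72 h (a higher number here means a weaker inhibitor of growth, a lower number a stronger inhibitor of growth), compound 2 `Cc1cccc(Cn2nc(Cl)c3c(NC(=O)c4csc5c(N)ncnc45)cccc32)n1` gives 8 nM, the lower of the two numbers measured so far, while compound 1 `Cc1cccc(Cn2nc(Br)c3c(NC(=O)c4csc5c(N)ncnc45)cccc32)n1` gives 27.5 nM. Compound 3 `Cc1cccc(Cn2nc(C)c3c(NC(=O)c4csc5c(N)ncnc45)cccc32)n1` differs from compound 2 in one place: methyl in place of chloro on an aromatic carbon. Going by the values given here, only one measured step bears on this change, and it sits on the same aromatic carbon: a 3.4-fold lower number from compound 1 to compound 2 (0.54 log units; beyond the scatter), with chloro in place of bromo. That step is modest, yet it shows that the group on this carbon can shift the number. Among the compounds with values here, no measured compound carries any guide to methyl beyond this single pair, so the forecast stays loose. Little change or a slight rise is expected, an estimated 1.9-fold higher number from compound 2 to compound 3 (0.27 log units; within the scatter) in this assay. For compound 3 the estimated value is 15 nM, with an expected range from 5 nM to 45 nM.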

Compound 3, concentration for 50% growth inhibition: 80 nM
Estimate against measurement, compound 3: 5.3-fold (0.73 log units) below; measured number outside the range, above it.
By their numbers in this assay, from the lowest: compound 2; then compound 1; then compound 3.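

In this assay, the step away from the halogens is the clearest so far: methyl on this aromatic carbon gives a higher number than either chloro (a 10-fold higher number from compound 2 to compound 3 (1.00 log units; beyond the scatter)) or bromo (a 2.9-fold higher number from compound 1 to compound 3 (0.46 log units; beyond the scatter)). The earlier pair showed only that one halogen could be exchanged for another with a modest shift, whereas chloro to methyl is the largest step among these three compounds, so two groups with the same heavy-atom count are far from interchangeable here. Nothing in hand explains why methyl differs from the halogens.

As far as these compounds go, whether fluoro, methoxy, a nitrile or an amine on this carbon would give a number lower than that of chloro stays open. The compounds shown also cannot tell whether this order would hold with another group in place of the (6-methylpyridin-2-yl)methyl group.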